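Tert-butyl for pyridinylethenyl at the benzylic aryl ring

The compounds below may be only part of what the source reports. "The series", "measured", "known", "first", "only" and "open" are said of these compounds alone.

Measured so far in an assay on isolated protein with Bile acid receptor (Homo sapiens) as the target; a lower number here means that less compound is needed, a higher number that more compound is needed for the effect:
compound 1 `COC(=O)/C=C/c1cccc(N(Cc2ccc(/C=C/c3c(C)cc(C)cc3C)cc2)C(=O)NC(C)C)c1` 431 nM
compound 2 `COC(=O)/C=C/c1cccc(N(Cc2ccc(/C=C/c3ccccn3)cc2)C(=O)C2CCCCC2)c1` 309 nM
compound 3 `COC(=O)/C=C/c1cccc(N(Cc2ccc(/C=C/c3ccccn3)cc2)C(=O)C(C)C)c1` 310 nM

All three values lie within the scatter of one another: compound 3 matches compound 2 (a 1.0-fold higher number from compound 2 to compound 3 (0.00 log units; within the scatter)), and compound 1 lies within the scatter of compound 2 as well. Going by the values given here, the only measured step changes the acyl group on the carbonyl carbon, not the group on the benzylic aryl ring.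

Compound 4 `COC(=O)/C=C/c1cccc(N(Cc2ccc(C(C)(C)C)cc2)C(=O)C2CCCCC2)c1` is not yet measured. It differs from compound 2 by tert-butyl in place of 2-(pyridin-2-yl)ethenyl on an aromatic carbon. Among the compounds with values here, no measured step touches this position, so nothing on record bears directly on the change; the series so far has been flat across its variations. A step in the weakening direction of moderate size is estimated, a 2.3-fold higher number from compound 2 to compound 4 (0.36 log units; beyond the scatter), with wide uncertainty. For compound 4 the expected value in this assay is 700 nM, in the range 250 nM to 2000 nM.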

Compound 4, half-maximal effective concentration: > 1000 nM
Compound 4 ended at the assay's limit; the forecaster's own chance of this, stated with the estimate: 10%; at least 1.4-fold (0.15 log units) between middle value and limit.
By their numbers in this assay, from the lowest: compounds 2, 3 and 1 (each within the scatter of the next). At a limit, above all of these: compound 4.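

Unlike the change on the carbonyl carbon, replacing the group on this aromatic carbon moves the read-out in this assay, with an at least 3.2-fold higher number from compound 2 to compound 4 (0.51 log units; beyond the scatter). The result for compound 4 is a limit of the assay, not a number: the limit of > 1000 nM in this assay, at which 1 of the 4 values shown sits. The full size of the step therefore stays unread.

On these data alone, it remains open whether the pyridine ring, the double bond or overall length matters, as compound 1 differs from compound 2 in more than one place. A 2-phenylethenyl group or a 2-(pyridin-2-yl)ethyl chain at this position would separate these.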